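This account rests on a few compounds, and the source may have more. Where it says the series, first, only, none or still open, it means among the compounds named here.

Working notes on the series.

Compound 2 `CCCSc1nc(Cl)c2c(n1)N(Cc1ccccc1)C(C(=O)N1CCN(C)CC1)N2` is the reference point for this step. Going by the values given here, in a functional assay on A549 cells (Homo sapiens) for antiproliferative activity, read by MTT assay, with a stated time of 72 h (a higher number here means a weaker inhibitor, a lower number a stronger inhibitor), compound 2 gives 2800 nM, the lowest of the two numbers measured so far. Among the compounds with values here, its only measured neighbour is compound 1 `CCCSc1nc(Cl)c2c(n1)N(Cc1cccs1)C(C(=O)N1CCN(C)CC1)N2`, which in this assay gives 6420 nM; the step of a 2.3-fold lower number from compound 1 to compound 2 (0.36 log units; beyond the scatter) is the single piece of structure–activity information available.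

Compound 3 `CCCSc1nc(Cl)c2c(n1)N(CCNC(=O)OC(C)(C)C)C(C(=O)N1CCN(C)CC1)N2` is not yet measured. Relative to compound 2 the change is ((tert-butoxycarbonyl)amino)methyl in place of phenyl on a saturated chain carbon bound to a nitrogen on an aromatic ring in a ring.

Within the data shown here, the one measured step, a 2.3-fold lower number from compound 1 to compound 2 (0.36 log units; beyond the scatter), exchanges one aromatic ring for another at the same place; it does not involve a chain group of the kind that enters in compound 3, so it bears on the present step only in showing that this position tolerates a modest change in the number. Among the measured compounds shown here, no measured pair tests removal of the ring altogether. The expectation for compound 3 is therefore weakly founded: a step of a 1.6-fold higher number from compound 2 to compound 3 (0.21 log units; within the scatter) is expected, with either direction plausible. Compound 3 is estimated at 4500 nM in this assay, within a range of 1500 nM to 14000 nM.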

Compound 3, half-maximal inhibitory concentration: 12400 nM
Estimate against measurement, compound 3: 2.8-fold (0.44 log units) below; the measured number falls inside the stated range.
By their numbers in this assay, from the lowest: compound 2; then compounds 1 and 3 (each within the scatter of the next).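

In this assay, this position now carries a group with no ring, and replacing phenyl with ((tert-butoxycarbonyl)amino)methyl gives a 4.4-fold higher number from compound 2 to compound 3 (0.65 log units; beyond the scatter). The position is therefore not indifferent to this change, and among the three compounds the benzyl of compound 2 keeps the lowest number, with its steps to both others beyond the scatter. An aromatic ring alone does not set the number, however: a 1.9-fold higher number from compound 1 to compound 3 (0.29 log units; within the scatter) places the ring-free chain of compound 3 within the scatter of the thiophen-2-yl group of compound 1, and no measured evidence accompanies these numbers to account for either step.

Going by these compounds, it remains open whether the step from phenyl reflects the loss of the ring or the presence of the tert-butoxycarbonyl group, as the two enter together in this single change. A free primary amine on the same ethyl chain, a plain butyl chain or a carboxylic acid at this position would help separate the two, and a longer chain carrying a phenyl ring would show whether the ring still counts when set further out.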